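From thiophen-2-yl to thiophen-3-yl on a shared core

The source may report more compounds than this note shows. Statements on the series, on what has been measured and on what is new or still open speak of the compounds shown alone.

In an ADME assay on L6 cells (Rattus norvegicus) for cytotoxicity, read by resazurin assay, with a stated time of 72 h (a lower number here means a stronger inhibitor, a higher number a weaker inhibitor), compound 1 `Cc1ccc(C(O)(c2ccc(Cl)cc2)c2cccnc2)cc1` gives 61000 nM, compound 2 `OC(c1ccc(Cl)cc1)(c1cccnc1)c1cccc(F)c1` gives 66000 nM and compound 3 `OC(c1ccc(Cl)cc1)(c1cccnc1)c1cccs1` gives 67700 nM. Compound 3 therefore stands level with the other two, its value lying within the scatter of both. Compound 4 `OC(c1ccc(Cl)cc1)(c1cccnc1)c1ccsc1` has thiophen-3-yl in place of thiophen-2-yl on a saturated chain carbon bound to two aromatic carbons and an oxygen on a saturated carbon. Three measured steps at this same place bear on the change. Thiophen-2-yl in place of 4-methylphenyl gives a 1.1-fold higher number from compound 1 to compound 3 (0.05 log units; within the scatter), thiophen-2-yl in place of 3-fluorophenyl gives a 1.0-fold higher number from compound 2 to compound 3 (0.01 log units; within the scatter), and 3-fluorophenyl in place of 4-methylphenyl gives a 1.1-fold higher number from compound 1 to compound 2 (0.03 log units; within the scatter). All three stay within the scatter, so no step beyond the scatter is expected in either direction in this assay. The expected step is a 1.0-fold lower number from compound 3 to compound 4 (0.01 log units; within the scatter). For compound 4 the estimated value is 66000 nM, with an expected range from 45000 nM to 95000 nM.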

Compound 4, half-maximal inhibitory concentration: > 100000 nM
Compound 4: a limit, no number; the forecaster's own chance of this, stated with the estimate: 5%; middle value at least 1.5-fold (0.18 log units) away from the limit.
By their numbers in this assay, from the lowest: compounds 1, 2 and 3 (each within the scatter of the next). At a limit, above all of these: compound 4.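

Compound 4 gives a limit and no number in this assay: the limit of > 100000 nM in this assay, at which 1 of the 4 values shown sits. The change from thiophen-2-yl to thiophen-3-yl, which leaves the atoms the same and only joins them differently, is thus the first at this place to end at a limit, whereas the three earlier groups gave values within the scatter of one another. Read as floors, the new steps are an at least 1.4-fold higher number from compound 3 to compound 4 (0.16 log units; that floor lies within the scatter), an at least 1.5-fold higher number from compound 2 to compound 4 (0.18 log units; that floor lies within the scatter) and an at least 1.6-fold higher number from compound 1 to compound 4 (0.21 log units; that floor lies within the scatter); each floor lies within the scatter, so the result hints at a real step without establishing one.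

Going by these compounds, the true size of these steps stays open. So does whether an amine, a carboxylic acid or a longer chain on this saturated chain carbon would stay level with compounds 1, 2 and 3 or reach the limit too.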